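The compounds below may be only part of what the source reports. "The series", "measured", "known", "first", "only" and "open" are said of these compounds alone.

Measured compounds:
compound 1 `CC(C)(C)c1nccc(-c2ccccc2O)n1` with 16300 ug/mL in an ADME assay on MDCK cells (Canis lupus familiaris) for cytotoxicity; on this read-out higher numbers stand for lower toxicity in this test and lower numbers for higher toxicity in this test;
compound 2 `Cc1ccc(O)c(-c2nc(C(C)(C)C)ncc2Sc2nccn2C)c1` with 116000 ug/mL in this assay.

Compound 1 carries a tert-butyl group and a 2-hydroxyphenyl group on a shared core. Among the two measured compounds, compound 1 stands lowest in this assay, and compound 2 gives a number that is higher and lies beyond the scatter of this test. Among the compounds with values here, compound 2 differs from compound 1 in more than one place, so its two values show only that a larger substituted analogue can reach a higher number.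

Compound 3 `Cn1cnnc1Sc1cnc(C(C)(C)C)nc1-c1ccccc1O` is the untested compound. It differs from compound 1 by the change ((4-methyl-4H-1,2,4-triazol-3-yl)sulfanyl in place of hydrogen on an aromatic carbon). The new group brings a five-membered aromatic ring joined through sulfur, much as compound 2 carries a sulfur-linked aromatic ring at the matching position. Within the data shown here, no measured pair differing in this single place is known, so the expected size of the step rests only on the gap between compound 1 and compound 2. For compound 3 the step of a 3.1-fold higher number from compound 1 to compound 3 (0.49 log units; beyond the scatter) is expected, an increase in the number, though a smaller one than compound 2 shows. The value for compound 3 is estimated at 50000 ug/mL, with a range from 15000 ug/mL to 160000 ug/mL.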

Compound 3, half-maximal cytotoxic concentration: 160000 ug/mL
Compound 3: the middle estimate sits 3.2-fold (0.51 log units) below what was measured; the measured number falls inside the stated range.
By their numbers in this assay, from the lowest: compound 1; then compounds 2 and 3 (each within the scatter of the next).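

Putting (4-methyl-4H-1,2,4-triazol-3-yl)sulfanyl in place of hydrogen on the aromatic carbon ortho to a 2-hydroxyphenyl group and para to a tert-butyl group gives a 9.8-fold higher number from compound 1 to compound 3 (0.99 log units; beyond the scatter) in this assay and so moves the read-out beyond the scatter. Within the data shown here, this is the first comparison in which only one place changes, so the rise can be tied to this single swap rather than to several differences at once, and at this position a group of this size goes with a higher number, which here stands for lower toxicity in this test. Nothing available explains why the number rises.

With a single step at this carbon, the compounds shown leave open whether the sulfur link, the triazole ring or the methyl group on that ring matters for the rise. From the compounds shown here alone, a simple methylsulfanyl group, a phenylsulfanyl group, an amine or a carboxylic acid on the same carbon would each test a different part of that question, and it also remains open whether the same step would appear on another core.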